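A few compounds are considered here, and "the series" means these few. Any claim that something is new, unique, unknown or untested is made for them only; others in the source may bear on it.

Compound 2, `Cc1nc(S(C)(=O)=O)ccc1Oc1ncnc(OC2CCN(C(=O)SC3CC3)CC2)c1F`, is one of two compounds that share a common core and have been measured in a functional assay on isolated protein for inhibition of Glucose-dependent insulinotropic receptor (Rattus norvegicus), read by HTRF and cAMP accumulation; on this read-out lower numbers stand for an effect already at smaller amounts and higher numbers for an effect only at larger amounts of compound. In this assay compound 2 gives 126 nM, the higher of the pair. For the measured compounds named here, its nearest neighbour is compound 1, `Cc1nc(S(C)(=O)=O)ccc1Oc1ncnc(OC2CCN(C(=O)OC3(C(F)(F)F)CCC3)CC2)c1F`, which in this assay gives 63.3 nM; the single step, a 2.0-fold higher number from compound 1 to compound 2 (0.30 log units; within the scatter), exchanges only the group carried on the carbonyl carbon and lies within the scatter.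

Compound 3, `Cc1nc(S(C)(=O)=O)ccc1Oc1ncnc(OC2CCN(C(=S)OC3(C)CC3)CC2)c1F`, has not yet been measured. It differs from compound 2 in one place: a group of 7 heavy atoms (5 carbon, 1 oxygen, 1 sulfur; one three-membered non-aromatic ring of carbon only) in place of a group of 6 heavy atoms (4 carbon, 1 oxygen, 1 sulfur; one three-membered non-aromatic ring of carbon only), on an amine nitrogen in a ring, on an amine nitrogen in a ring of a six-membered non-aromatic ring with 1 nitrogen, three ring bonds from the ring atom that bears a large group.

Going by the values given here, only one measured step touches this part of the molecule, the step from compound 1 to compound 2, and it stayed within the scatter. On that basis the step from compound 2 to compound 3 is expected to be small, a 1.1-fold lower number from compound 2 to compound 3 (0.02 log units; within the scatter), with no direction that can be claimed beyond the scatter. For compound 3 in this assay a value of 120 nM is therefore estimated, with a range from 40 nM to 400 nM.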

Compound 3, half-maximal effective concentration: 48.8 nM
Estimate against measurement, compound 3: 2.5-fold (0.39 log units) above; the measured number falls inside the stated range.
By their numbers in this assay, from the lowest: compounds 3, 1 and 2 (each within the scatter of the next, the first and the last beyond it).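

For the compounds shown here, compound 2 and compound 3 give the first step at this position that clears the scatter in this assay: a 2.6-fold lower number from compound 2 to compound 3 (0.41 log units; beyond the scatter) shows that the number responds to a change confined to the group on the amine nitrogen in a ring, even though that group only grows from 6 to 7 heavy atoms. The comparison with the larger group of 11 heavy atoms, a 1.3-fold lower number from compound 1 to compound 3 (0.11 log units; within the scatter), shows that a much smaller group can give a number within the scatter of compound 1, so in these compounds a large group on this nitrogen is not required for a number in that range. No measurement available here explains why the number moved.

The step from compound 2 to compound 3 alters two things at once, since the sulfur moves from the link to the ring into the thiocarbonyl and a methyl group appears on the cyclopropane ring, so the compounds shown cannot say which of the two accounts for it. Going by these compounds, a plain cyclopropyl group joined through oxygen to the same thiocarbonyl would separate these two changes, and whether the shift holds for an isopropyl group in the same place remains open.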